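A few compounds are considered here, and "the series" means these few. Any claim that something is new, unique, unknown or untested is made for them only; others in the source may bear on it.

Within the data shown here, compound 2 `Cc1cc(NC(=O)Nc2ccc(SC(F)(F)F)cc2)c2ccccc2n1` is the only member of the series with a numbered value in an ADME assay on HEK293 cells (Homo sapiens) for cytotoxicity, with a stated time of 72 h (a lower number here means that less compound is needed, a higher number that more compound is needed for the effect), where compound 2 gives 13000 nM. Compound 1 `COc1ccc(NC(=O)Nc2cc(C)nc3ccccc23)cc1` gives in this assay only a limit, > 25000 nM. Among the measured compounds shown here, the single measured step, an at least 1.9-fold lower number from compound 1 to compound 2 (0.28 log units; that floor lies within the scatter), is therefore a floor set by the limit of > 25000 nM in this assay, at which 1 of the 2 values shown sits, rather than a full step of known size. Compound 3 `Cc1cc(NC(=O)Nc2ccc(C(F)(F)F)cc2)c2ccccc2n1` differs from compound 2 by trifluoromethyl in place of (trifluoromethyl)sulfanyl on an aromatic carbon. For the measured compounds named here, no measured step touches this change, and the one step that exists does not reach beyond the scatter. With one number and one limit to go on, no shift beyond the scatter is expected for compound 3 in this assay. For compound 3 the step is expected as a 1.2-fold higher number from compound 2 to compound 3 (0.06 log units; within the scatter). Compound 3 is estimated in this assay at 15000 nM, within 7000 nM to 30000 nM.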

Compound 3, half-maximal effective concentration: 25000 nM
Compound 3: middle estimate off by 1.7-fold (0.22 log units), on the low side; measured number inside the range.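

In this assay, among these compounds, trifluoromethyl in place of (trifluoromethyl)sulfanyl on the aromatic carbon para to a large group gives a 1.9-fold higher number from compound 2 to compound 3 (0.28 log units; within the scatter) as the only step of known size. At this position, removing the sulfur atom from the group therefore does not separate the two compounds beyond the scatter, whereas the earlier step offered only a floor. Trifluoromethyl in place of methoxy on an aromatic carbon gives a number no higher from compound 1 to compound 3 (the limit leaves the size open) and this step cannot be read, since compound 1 carries only a limit: the limit of > 25000 nM in this assay, at which 1 of the 3 values shown sits.

On these data alone, whether a group of another kind at this position, such as an amine or a carboxylic acid, would shift the number beyond the scatter in this assay remains open. As far as these compounds go, the true size of the change from methoxy to either fluorinated group also remains open.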